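A few compounds are considered here, and "the series" means these few. Any claim that something is new, unique, unknown or untested is made for them only; others in the source may bear on it.

Working notes on the series. Compound 3 `COC(=O)N1CCN(CCN2CCC(CNC(=O)c3cccc4[nH]c(C(C)C)nc34)CC2)CC1` gives 1.59 nM in an assay on isolated protein for binding affinity to 5-hydroxytryptamine receptor 4 (Homo sapiens); on this read-out lower numbers stand for stronger inhibition and higher numbers for weaker inhibition. Among the three measured compounds it holds the second highest number: the step of a 2.0-fold higher number from compound 2 to compound 3 (0.30 log units; within the scatter) from compound 2 `CC(C)c1nc2c(C(=O)NCC3CCN(CCN4CCN(S(C)(=O)=O)CC4)CC3)cccc2[nH]1` with 0.794 nM to compound 3 lies within the scatter, while compound 1 `CS(=O)(=O)N1CCN(CC(O)CN2CCC(NC(=O)c3cccc4[nH]cnc34)CC2)CC1` with 251 nM stands far above compound 3; compound 1 differs from compound 3 in more than one place, so no single step is drawn between them.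

Compound 4 `COC(=O)N(C)CC(O)CN1CCC(CNC(=O)c2cccc3[nH]c(C(C)C)nc23)CC1` is not yet measured in this assay. It differs from compound 3 by 1-hydroxy-2-((methoxycarbonyl)(methyl)amino)ethyl in place of (4-(methoxycarbonyl)piperazin-1-yl)methyl on a saturated chain carbon bound to an amine nitrogen in a ring. For the measured compounds named here, the one measured step, a 2.0-fold higher number from compound 2 to compound 3 (0.30 log units; within the scatter), concerns the group on the amine nitrogen of the piperazine and not the piperazine itself, so it does not bear directly on this change. Compound 1 carries a hydroxy-bearing chain and an intact piperazine together with a different core, so its high number cannot be assigned to the chain alone. Going by the values given here, the data therefore give no step that matches the change from compound 3 to compound 4. Compound 4 is expected to give 20 nM, between 3 nM and 150 nM, a weakening estimated as a 13-fold higher number from compound 3 to compound 4 (1.10 log units; beyond the scatter).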

Compound 4, inhibition constant: 3.98 nM
For compound 4 the middle estimate is 5.0-fold (0.70 log units) above the measured one; the measured number falls inside the stated range.
By their numbers in this assay, from the lowest: compounds 2 and 3 (each within the scatter of the next); then compound 4; then compound 1.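

In this assay, the open-chain 1-hydroxy-2-((methoxycarbonyl)(methyl)amino)ethyl group takes the place of (4-(methoxycarbonyl)piperazin-1-yl)methyl at only a modest cost, a 2.5-fold higher number from compound 3 to compound 4 (0.40 log units; beyond the scatter), so this position on a saturated chain carbon bound to an amine nitrogen in a ring does not depend strictly on the piperazine ring. Measured against the methylsulfonyl piperazine, the same open chain also gives a modest step, a 5.0-fold higher number from compound 2 to compound 4 (0.70 log units; beyond the scatter), so in the shared core the hydroxy-bearing chain costs far less here than the high number of compound 1 might have suggested, although compound 1 differs in more than one place. No measurement on hand accounts for the size of either step.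

From the compounds shown here alone, compound 3 and compound 4 differ at once in the ring, the hydroxy group and the carbamate nitrogen, so the part of the change that carries the step remains open. Also open, going by these compounds, is how this position would respond to a chain ending in a primary amine or a carboxylic acid in place of the methoxycarbonyl group.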